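Dropping the Methyl from the Benzyl Group of Compound 1

The source may report more compounds than this note shows. Statements on the series, on what has been measured and on what is new or still open speak of the compounds shown alone.

Of the compounds shown here, three sharing one core have been tested in an assay on microsomes from liver for inhibition of 3-hydroxy-3-methylglutaryl-coenzyme A reductase (Rattus norvegicus), read by scintillation counting, with stated times of 0.5 h and 0.75 h; on this read-out lower numbers stand for stronger inhibition and higher numbers for weaker inhibition. Compound 1 `Cc1ccccc1CNC(=O)c1nc(-c2ccc(F)cc2)n(CC[C@@H](O)C[C@@H](O)CC(=O)O)c1C1CC1` gives 4.9 nM. Compound 2 `Cc1c(C(=O)NCc2ccccc2)nc(-c2ccc(F)cc2)n1CC[C@@H](O)C[C@@H](O)CC(=O)O` gives 94 nM, and compound 3 `COc1cccc(CNC(=O)c2nc(-c3ccc(F)cc3)n(CC[C@@H](O)C[C@@H](O)CC(=O)O)c2C2CC2)c1` gives 1.2 nM. Among these three, compound 1 holds the second highest number: compound 3 is nearest, with a 4.1-fold lower number from compound 1 to compound 3 (0.61 log units; beyond the scatter), while compound 2 is furthest, its number standing well above that of compound 1.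

Compound 4 `O=C(O)C[C@H](O)C[C@H](O)CCn1c(-c2ccc(F)cc2)nc(C(=O)NCc2ccccc2)c1C1CC1` has not yet been measured. It differs from compound 1 by hydrogen in place of methyl on an aromatic carbon. Within the data shown here, the only measured step touching the same part of the molecule is a 4.1-fold lower number from compound 1 to compound 3 (0.61 log units; beyond the scatter), which exchanged the whole aromatic group and lowered the number only modestly. Compound 2 also carries a plain benzyl group, but it differs from compound 1 in a second place too, so its value cannot be read as a single step. Removing one methyl is a smaller change than either comparison, so a step within or just beyond the scatter is expected, if anything toward a higher number. Compound 4 is therefore estimated at 8 nM, within 3 nM to 20 nM. That expected shift amounts to a 1.6-fold higher number from compound 1 to compound 4 (0.21 log units; within the scatter).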

Compound 4, half-maximal inhibitory concentration: 1.4 nM
Estimate against measurement, compound 4: 5.7-fold (0.76 log units) above, outside the stated range (below it).
By their numbers in this assay, from the lowest: compounds 3 and 4 (each within the scatter of the next); then compound 1; then compound 2.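

In this assay the methyl on the benzyl group is not needed: taking it away gives a 3.5-fold lower number from compound 1 to compound 4 (0.54 log units; beyond the scatter) and so improves inhibition modestly, in the direction opposite to a loss. The plain benzyl group and the 3-methoxy version cannot be told apart, with a 1.2-fold higher number from compound 3 to compound 4 (0.07 log units; within the scatter) lying within the scatter, so the methoxy group is not required to reach this level once the 2-methyl group is absent. The cleanest comparison at the other changed place shows a far larger effect, with cyclopropyl in place of methyl giving a 67-fold lower number from compound 2 to compound 4 (1.83 log units; beyond the scatter), so that place counts for much more than the benzyl methyl. Nothing measured here explains any of these steps.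

Still open, from the compounds shown here alone, is how a chlorine, a hydroxyl or an amine on the phenyl ring would read. A longer chain between the amide nitrogen and the phenyl ring, or isopropyl in place of cyclopropyl, also remains untested within the compounds shown.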